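The source may report more compounds than this note shows. Statements on the series, on what has been measured and on what is new or still open speak of the compounds shown alone.

This study looks at a small set of related molecules tested in a functional assay on Jurkat cells (Homo sapiens) for activation, with a stated time of 24 h; a higher number here means that more compound is needed for the effect, a lower number that less compound is needed. Compound 1, with the structure `COc1ccc(CNc2ccc(C3CCCCC3)cc2)c(O)c1`, is the starting point. In this assay compound 1 gives "not active" (no number reported), so no concentration value stands for it. Two further compounds share the hydroxybenzyl portion but carry a different group at the far end. Compound 2, `COc1ccc(-c2ccc(NCc3ccccc3O)cc2)cc1`, in this assay gives 580 nM. Compound 3, `Oc1ccccc1CNc1ccc(-c2ccc(OC(F)(F)F)cc2)cc1`, in this assay gives "not active" (no number reported), again with no number. Of the three, only compound 2 carries a value, and compound 1 stands with compound 3 among those without one.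

The compound not yet measured is compound 4, `Oc1ccccc1CNc1ccc(C2CCCCC2)cc1`. It differs from compound 1 by hydrogen in place of methoxy on an aromatic carbon. After this change the hydroxybenzyl part of compound 4 matches that of compound 2 and compound 3, while the cyclohexyl group of compound 1 stays. No number stands for compound 1; the size of the step cannot therefore be counted. If the change has any effect in this assay, it would most plausibly be toward less compound being needed, with outcomes ranging from no measurable effect to a value of the kind seen for compound 2. Compound 4 is expected to give 2500 nM, with a range of 500 nM to 15000 nM, and a considerable chance that only a limit is reported.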

Compound 4, half-maximal effective concentration: 8800 nM
Compound 4: middle estimate off by 3.5-fold (0.55 log units), on the low side; the measured number falls inside the stated range.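

Compound 4 gives 8800 nM, but compound 1 gives "not active" (no number reported), so the size of the change between these two compounds cannot be read. No measured evidence accounts for this result. The compounds shown leave open how much swapping methoxy for hydrogen at this place changes the amount of compound needed.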